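The source may hold more compounds than are shown below. What is called first, only, known or untested is meant among the compounds shown, and "the series" means these compounds.

Measured in a functional assay on SMMC-7721 cells (Homo sapiens) for cytotoxicity, read by MTT assay, with a stated time of 24 h; on this read-out lower numbers stand for stronger inhibition and higher numbers for weaker inhibition:
- Compound 1 `O=C1/C(=C/c2cccnc2)CN(S(=O)(=O)c2ccc([N+](=O)[O-])cc2)C/C1=C\c1ccccc1C(F)(F)F`: 15900 nM
- Compound 2 `O=C1/C(=C/c2cccnc2)CN(S(=O)(=O)c2ccc(C(F)(F)F)cc2)C/C1=C\c1ccccc1C(F)(F)F`: 1730 nM
- Compound 3 `O=C1/C(=C/c2cccnc2)CN(S(=O)(=O)c2ccc(F)cc2)C/C1=C\c1ccccc1C(F)(F)F`: 6390 nM

Compound 3 sits in the middle of these three numbers, with compound 1 higher and compound 2 lower. The next compound, compound 4 `O=C1/C(=C/c2cccnc2)CN(S(=O)(=O)c2ccc(Cl)cc2)C/C1=C\c1ccccc1C(F)(F)F`, differs from compound 3 in a single substituent: chloro in place of fluoro on an aromatic carbon. This puts chloro in place of fluoro on an aromatic carbon, para to a large group.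

For the measured compounds named here, no measured step makes this exact swap, but three steps change the group at this same place. Replacing nitro with trifluoromethyl gave a 9.2-fold lower number from compound 1 to compound 2 (0.96 log units; beyond the scatter), and replacing nitro with fluoro gave a 2.5-fold lower number from compound 1 to compound 3 (0.40 log units; beyond the scatter). Replacing trifluoromethyl with fluoro gave a 3.7-fold higher number from compound 2 to compound 3 (0.57 log units; beyond the scatter). All three are modest, so the swap to chloro should not be a large one. Chloro is expected to fall between fluoro and trifluoromethyl, though this is a judgement from only three compounds.

The expected change is a modest move to a lower number, a 2.1-fold lower number from compound 3 to compound 4 (0.33 log units; beyond the scatter). For compound 4 the estimated value is 3000 nM, with an expected range of 1300 nM to 8000 nM.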

Compound 4, half-maximal inhibitory concentration: 4880 nM
Estimate against measurement, compound 4: 1.6-fold (0.21 log units) below, within the range that was stated.
By their numbers in this assay, from the lowest: compound 2; then compounds 4 and 3 (each within the scatter of the next); then compound 1.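

In this assay, chloro and fluoro cannot be told apart at this place on the ring, with a 1.3-fold lower number from compound 3 to compound 4 (0.12 log units; within the scatter). The other two steps are larger: there is a 2.8-fold higher number from compound 2 to compound 4 (0.45 log units; beyond the scatter), and also a 3.3-fold lower number from compound 1 to compound 4 (0.51 log units; beyond the scatter), so among these four compounds, compound 2 remains the strongest and compound 1 the weakest. Nothing available explains these differences.

The compounds shown leave open how an amine, a carboxylic acid or a methoxy group would behave on this aromatic carbon, para to a large group. They also leave open whether the same order of groups would hold if another part of the shared core were changed.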